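Quinoxaline diamines: sulfanyl to benzylamino at the phenyl-bearing ring

The source may hold more compounds than are shown below. What is called first, only, known or untested is meant among the compounds shown, and "the series" means these compounds.

Measured compounds:
compound 1 `Nc1cc(N)c2nc(-c3ccccc3)c(Sc3ccc(F)cc3)nc2c1` 17800 nM
compound 2 `CCOC(=O)[C@H](CCC(=O)O)NC(=O)c1ccc(Oc2nc3cc(N)cc(N)c3nc2-c2ccccc2)cc1` 40700 nM
compound 3 `CCOC(=O)[C@H](CCC(=O)O)NC(=O)c1ccc(CNc2nc3cc(N)cc(N)c3nc2-c2ccccc2)cc1` — limit only

In a functional assay on SF-268 cells (Homo sapiens) for inhibition, read by sulforhodamine B assay, with a stated time of 48 h (a lower number here means a stronger inhibitor of growth, a higher number a weaker inhibitor of growth), compound 1 gives 17800 nM, the lowest of the two numbers, with compound 2 at 40700 nM beyond the usual scatter above it. In this assay compound 3 gives < 100000 nM, a limit of the assay rather than a number. Compound 3 thus reaches only (the limit of < 100000 nM in this assay, at which 1 of the 3 values shown sits).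

Compound 4 `Nc1cc(N)c2nc(-c3ccccc3)c(NCc3ccc(F)cc3)nc2c1` differs from compound 1 by (4-fluorobenzyl)amino in place of (4-fluorophenyl)sulfanyl on an aromatic carbon. Among the measured compounds shown here, no measured pair shows this change directly. The shared core and the 4-fluorophenyl portion stay; the sulfur link gives way to a (4-fluorobenzyl)amino group with one hydrogen-bond donor. The expected step from compound 1 to compound 4 is a 1.6-fold higher number from compound 1 to compound 4 (0.20 log units; within the scatter), a small weakening. Compound 4 is therefore estimated at 28000 nM, within 9000 nM to 85000 nM.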

Compound 4, concentration for 50% growth inhibition: 2820 nM
Compound 4: the middle estimate sits 9.9-fold (1.00 log units) above what was measured; the measured number lies below the stated range.
By their numbers in this assay, from the lowest: compound 4; then compound 1; then compound 2.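

Among the compounds shown here, on this aromatic carbon, ortho to a phenyl group, (4-fluorobenzyl)amino in place of (4-fluorophenyl)sulfanyl gives a 6.3-fold lower number from compound 1 to compound 4 (0.80 log units; beyond the scatter) in this assay, the first single-place step. The position therefore responds to a change of link while the 4-fluorophenyl portion stays, and the entering group carries a hydrogen-bond donor that the leaving group lacks. No measurement shown accounts for the step.

Still open, as far as these compounds go, is whether the step follows the nitrogen or the extra carbon. A (4-fluorophenyl)amino group would separate the two.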